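This account rests on a few compounds, and the source may have more. Where it says the series, first, only, none or still open, it means among the compounds named here.

Measured so far in an in vivo ADME assay on the whole organism for pharmacokinetics, with Canis familiaris (Canis lupus familiaris) as the target; a higher number here means faster removal of the compound, a lower number slower removal:
- compound 1 `CN(C)Cc1ccccc1-c1ccc(N2CCc3c(C(F)(F)F)nn(-c4ccc5onc(N)c5c4)c3C2=O)c(F)c1` gives 17.5 mL/min/kg
- compound 2 `Nc1noc2ccc(-n3nc(C(F)(F)F)c4c3C(=O)N(c3ccc(-c5ccccc5CN5CCC(O)CC5)cc3)CC4)cc12` gives 3.5 mL/min/kg

Compound 2 stands lowest of the two in this assay, and its gap to compound 1 lies beyond the scatter. Compound 3 `CN(C)Cc1ccccc1-c1ccc(N2CCc3c(C(F)(F)F)nn(-c4ccc5onc(N)c5c4)c3C2=O)cc1` has not yet been measured. The change from compound 2 is dimethylamino in place of 4-hydroxypiperidin-1-yl on a saturated chain carbon bound to an aromatic carbon. Within the data shown here, no measured pair isolates this change, so the expectation rests on one comparison. Compound 1 also carries dimethylamino and gives 17.5 mL/min/kg, so an upward step beyond the scatter is expected. The estimated step is a 3.7-fold higher number from compound 2 to compound 3 (0.57 log units; beyond the scatter). For compound 3 the expected value is 13 mL/min/kg, with an estimated range of 6 mL/min/kg to 26 mL/min/kg.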

Compound 3, clearance: 16.3 mL/min/kg
Beside the measured number, compound 3's estimate is 1.3-fold (0.10 log units) below it, within the range that was stated.
By their numbers in this assay, from the lowest: compound 2; then compounds 3 and 1 (each within the scatter of the next).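

In this assay, dimethylamino in place of 4-hydroxypiperidin-1-yl on a saturated chain carbon bound to an aromatic carbon now stands as a clean single change, giving a 4.7-fold higher number from compound 2 to compound 3 (0.67 log units; beyond the scatter). Hydrogen in place of fluoro on an aromatic carbon gives a 1.1-fold lower number from compound 1 to compound 3 (0.03 log units; within the scatter), so among these compounds only the amine change produces a step that can be read. Nothing at hand explains the size of either step.

Open, as far as these compounds go, is whether the step follows the ring of 4-hydroxypiperidin-1-yl or its hydroxyl, a question that piperidin-1-yl without the hydroxyl, or morpholin-4-yl, could separate. Also open, from the compounds shown here alone, is whether fluoro stays without effect when 4-hydroxypiperidin-1-yl sits on the same chain carbon.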